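The source may hold more compounds than are shown below. What is called first, only, known or untested is meant among the compounds shown, and "the series" means these compounds.

Compound 1 `Cc1oc(CCC(=O)O)cc1COc1ccc(-c2ccccc2)cc1`, 80 nM
Compound 2 `COc1ccc(-c2ccc(OCc3cc(C(=O)NS(=O)(=O)c4c(C)noc4C)oc3C)cc2)c(C)c1`, 24 nM
Compound 3 `COc1ccc(-c2ccc(OCc3cc(C(=O)NS(=O)(=O)c4ccccc4)oc3C)cc2)cc1`, 5 nM

Of the compounds shown here, three have been measured in an assay on cells for displacement of a labelled ligand from prostaglandin E2 receptor EP4 subtype (Homo sapiens), read by scintillation counting; on this read-out higher numbers stand for weaker inhibition and lower numbers for stronger inhibition. Compound 1 gives 80 nM, the highest of the three numbers. Compound 2 comes nearest with 24 nM, a number lower than that of compound 1 by more than the usual scatter, and compound 3 stands furthest with 5 nM, lower again by a gap well beyond the scatter. Compounds 2 and 3 differ from compound 1 in several places at once, so none of these gaps can be read as the effect of a single change.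

The unmeasured compound 4 `Cc1oc(C(=O)O)cc1COc1ccc(-c2ccccc2)cc1` is related to compound 1 by one change: carboxy in place of 2-carboxyethyl on an aromatic carbon. Within the data shown here, no step between two measured compounds matches this change, so the expectation rests on general experience only. The shorter group is expected to give a weaker result, the number for compound 4 moving above that of compound 1 by a step of a 3.1-fold higher number from compound 1 to compound 4 (0.49 log units; beyond the scatter) beyond the scatter, though with wide uncertainty. Compound 4 is therefore expected to show about 250 nM in this assay, within a range of 50 nM to 1500 nM.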

Compound 4, inhibition constant: 420 nM
For compound 4 the middle estimate is 1.7-fold (0.23 log units) below the measured one; measured number inside the range.
By their numbers in this assay, from the lowest: compound 3; then compound 2; then compound 1; then compound 4.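

In this assay, among these compounds, carboxy in place of 2-carboxyethyl, on the aromatic carbon next to the ring oxygen, gives a 5.3-fold higher number from compound 1 to compound 4 (0.72 log units; beyond the scatter), the first step here that can be read as one change in one place. It shows that the number responds to the group at this position, even though both groups end in the same acid function and differ only in the chain that carries it, and that the shorter group goes with the higher number in this pair. Nothing shown accounts for the size or direction of this step.

From the compounds shown here alone, whether a longer chain such as 3-carboxypropyl, or an amine in place of the acid, would move the number further remains open. Also open, going by these compounds, is whether the same step would appear on the cores of compound 2 and compound 3, which carry a sulfonyl amide at this position.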